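The compounds below may be only part of what the source reports. "The series", "measured", "known", "first", "only" and "open" are said of these compounds alone.

Measured compounds in an assay on isolated protein for inhibition of Dihydrofolate reductase (Homo sapiens), read by spectrophotometry, using NADPH, with stated times of 5 s and 6 min, tested at 5 uM; on this read-out higher numbers stand for a stronger effect at the one concentration tested and lower numbers for a weaker effect:
compound 1 `COc1ccc(OCCCON2C(N)=NC(N)=NC23CCOCC3)cc1` — > 90%, a limit of the assay
compound 2 `NC1=NC2(CCOCC2)N(OCCCOc2ccc(Cl)cc2)C(N)=N1` — > 90%, a limit of the assay
compound 3 `NC1=NC2(CCOCC2)N(OCCCOc2ccc(Cl)cc2Cl)C(N)=N1` — > 90%, a limit of the assay

Compound 3 stands at the limit of this assay (the limit of > 90% in this assay, at which 3 of the 3 values shown sit). Going by the values given here, the three measured values therefore allow no ordering among the compounds. Compound 4 `NC1=NC2(CCOCC2)N(OCCCOc2cc(Cl)c(Cl)cc2Cl)C(N)=N1` differs from compound 3 by chloro in place of hydrogen on an aromatic carbon. The step that most resembles this change, a step that the two limits leave unreadable from compound 2 to compound 3, has no readable size, both of its ends being limits; the same holds for a step that the two limits leave unreadable from compound 1 to compound 2 and a step that the two limits leave unreadable from compound 1 to compound 3. Every chloro-for-hydrogen or chloro-for-methoxy change so far has left the inhibition at the limit, so no step beyond the scatter is expected here. Compound 4 is expected to give 95% in this assay, within 85% to 100%. The expected step is thus a step that the limit leaves unreadable from compound 3 to compound 4.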

Compound 4, a percentage reported as inhibition, at one concentration (the size of the read-out at that concentration, not a potency): > 90%
Compound 4 was reported as a limit; the forecaster's own chance of this, stated with the estimate: 85%; the middle value is on the limit's open side.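

Compound 4 sits at the limit of this assay, as do compound 1, compound 2 and compound 3, so no step among them can be read: the limit of > 90% in this assay, at which 4 of the 4 values shown sit.

The compounds shown leave open whether any of these changes on the aromatic ring alters the inhibition.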